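A few compounds are considered here, and "the series" means these few. Any claim that something is new, unique, unknown or untested is made for them only; others in the source may bear on it.

The measured compounds in an ADME assay on HCT-116 cells (Homo sapiens) for cytotoxicity, read by CellTiter-Glo, with a stated time of 72 h (a lower number here means a stronger inhibitor, a higher number a weaker inhibitor), are these:

Compound 1, `CC1CCN(C2CCN(S(=O)(=O)c3ccc(F)cc3F)CC2)CC1`: in this assay compound 1 gives > 5000 nM, which is a limit of the assay.
Compound 2, `CC1CCN(C2CCN(S(=O)(=O)c3cccnc3Cl)CC2)CC1`: in this assay compound 2 gives > 10000 nM, which is a limit of the assay.
Compound 3, `CC1CCN(C2CCN(S(=O)(=O)c3ccc(C#N)cc3)CC2)CC1`: in this assay compound 3 gives > 5000 nM, which is a limit of the assay.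

For the measured compounds named here, compound 3 thus stands at the limit of > 5000 nM in this assay, at which 2 of the 3 values shown sit, and no compound among the three has a numerical value; the remaining one sits at the limit of > 10000 nM in this assay, at which 1 of the 3 values shown sits. All three steps among them exchange the aryl group on the sulfonyl sulfur, and each is unreadable: a step that the two limits leave unreadable from compound 1 to compound 2, a step that the two limits leave unreadable from compound 1 to compound 3 and a step that the two limits leave unreadable from compound 2 to compound 3.

Compound 4, `CC1CCN(C2CCN(S(=O)(=O)c3nccn3C)CC2)CC1`, differs from compound 3 by 1-methyl-1H-imidazol-2-yl in place of 4-cyanophenyl on a sulfonyl sulfur. Going by the values given here, the three measured steps are the ones that bear on this change, and since none of them can be read, no step in this assay beyond the scatter is expected in either direction. Compound 4 is therefore expected to give 20000 nM, in the range 5000 nM to 100000 nM, an estimated step that the limit leaves unreadable from compound 3 to compound 4, most likely reported again only as a limit.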

Compound 4, half-maximal inhibitory concentration: > 10000 nM
Compound 4: no number, only a limit; the forecaster's own chance of this, stated with the estimate: 85%; the middle value is on the limit's open side.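

In this assay compound 4 gives > 10000 nM, which is a limit of the assay. The steps from compound 4 to compound 1, compound 2 and compound 3 cannot be read. The compounds shown leave open whether the group on the sulfonyl sulfur changes the value in this assay at all.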